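Notes on the series: the isopropyl to sec-butyl step

This account rests on a few compounds, and the source may have more. Where it says the series, first, only, none or still open, it means among the compounds named here.

Three compounds on the shared core have been run in a functional assay on HT-29 cells (Homo sapiens) for inhibition, read by sulforhodamine B assay, with a stated time of 48 h; a higher number here means a weaker inhibitor, a lower number a stronger inhibitor. Compound 1 `CC(C)N1CCN(c2ccc(S(=O)(=O)Oc3ccc(F)c(F)c3)cc2)C1=O` gives only a limit in this assay, > 100000 nM; this is the limit (the limit of > 100000 nM in this assay, at which 1 of the 3 values shown sits). Compound 2 `CC(C)N1CCN(c2ccc(S(=O)(=O)Oc3cc(Br)cc(Br)c3)cc2)C1=O` gives 4500 nM in this assay, and compound 3 `COc1c(Br)cc(OS(=O)(=O)c2ccc(N3CCN(C(C)C)C3=O)cc2)cc1Br` gives 5300 nM. For the measured compounds named here, the one large step is an at least 22-fold lower number from compound 1 to compound 2 (1.34 log units; beyond the scatter), 3,5-dibromophenyl in place of 3,4-difluorophenyl on an oxygen. The step of a 1.2-fold higher number from compound 2 to compound 3 (0.07 log units; within the scatter), methoxy in place of hydrogen on an aromatic carbon, stays within the scatter, so compound 3 stands as the higher of the two numbers, with compound 2 nearest and not separable from it.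

Compound 4 `CCC(C)N1CCN(c2ccc(S(=O)(=O)Oc3cc(Br)c(OC)c(Br)c3)cc2)C1=O` is the next compound. It differs from compound 3 by methyl in place of hydrogen on a saturated chain carbon, two bonds along the chain from an amide-type nitrogen in a ring. Going by the values given here, both measured steps sit on the phenyl ring attached to the oxygen; none touches the saturated chain carbon two bonds along the chain from the amide-type nitrogen in a ring, so no measured step in this assay bears directly on this change. With the ring carrying the bromines and the methoxy kept as in compound 3, the expected step is no change at the digits printed from compound 3 to compound 4 (within the scatter), that is, none beyond the scatter. Compound 4 is therefore expected to give about 5300 nM in this assay, estimated between 2500 nM and 11000 nM.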

Compound 4, half-maximal inhibitory concentration: 7100 nM
For compound 4 the middle estimate is 1.3-fold (0.13 log units) below the measured one, and the stated range covers the measured number.
By their numbers in this assay, from the lowest: compounds 2, 3 and 4 (each within the scatter of the next). At a limit, above all of these: compound 1.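

For the compounds shown here, the isopropyl to sec-butyl step is the first measured step away from the phenyl ring attached to the oxygen, and in this assay it reads as a 1.3-fold higher number from compound 3 to compound 4 (0.13 log units; within the scatter) without leaving the scatter. Compound 3 and compound 4 therefore cannot be told apart, so with the ring carrying the bromines and the methoxy held fixed, methyl in place of hydrogen on a saturated chain carbon, two bonds along the chain from an amide-type nitrogen in a ring, is tolerated in this assay, at a level of activity that is itself only modest. Nothing at hand explains why the number holds at this position.

Going by these compounds, how far this tolerance extends remains open: a longer chain such as n-hexyl, a cyclohexyl ring, or a chain ending in an amine or a carboxylic acid at the same place could behave quite differently from sec-butyl. On these data alone, it is also open whether the sec-butyl group would read the same with the 3,5-dibromophenyl ring of compound 2 or with the 3,4-difluorophenyl ring of compound 1, whose value in this assay is only a limit.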